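Replacing the Furan Ring with a Saturated Carbocycle

The source may hold more compounds than are shown below. What is called first, only, known or untested is meant among the compounds shown, and "the series" means these compounds.

Three analogues share one core and differ only in the group on a carbonyl carbon. Compound 1 `CC(=O)/N=C1\NC2(CCCCO2)CCS1` gives 3.1 mg/kg in a functional assay on the whole organism (strain CF-1) with Mus musculus as the target, in the writhing test, with a stated time of 15 min; on this read-out higher numbers stand for an effect only at larger amounts of compound and lower numbers for an effect already at smaller amounts; compound 2 `O=C(/N=C1\NC2(CCCCO2)CCS1)c1ccc(Cl)cc1` gives 1.1 mg/kg; compound 3 `O=C(/N=C1\NC2(CCCCO2)CCS1)c1ccco1` gives 42 mg/kg, the highest of the three numbers. The measured steps are a 2.8-fold lower number from compound 1 to compound 2 (0.45 log units; beyond the scatter), a 14-fold higher number from compound 1 to compound 3 (1.13 log units; beyond the scatter) and a 38-fold higher number from compound 2 to compound 3 (1.58 log units; beyond the scatter). Compound 4 `CC1(C(=O)/N=C2\NC3(CCCCO3)CCS2)CCCCC1` carries 1-methylcyclohexyl in place of furan-2-yl on a carbonyl carbon. Going by the values given here, no measured step swaps furan-2-yl for a ring of carbon only, yet a lower number is expected for compound 4 because a 14-fold higher number from compound 1 to compound 3 (1.13 log units; beyond the scatter) and a 38-fold higher number from compound 2 to compound 3 (1.58 log units; beyond the scatter) both show furan-2-yl giving the weakest effect. The estimated step for compound 4 is an 8.4-fold lower number from compound 3 to compound 4 (0.92 log units; beyond the scatter). Compound 4 is therefore expected at 5 mg/kg, in the range 1.5 mg/kg to 20 mg/kg.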

Compound 4, dose for half-maximal effect: > 200 mg/kg
Compound 4: a limit, no number; the forecaster's own chance of this, stated with the estimate: 10%; middle value at least 40-fold (1.60 log units) away from the limit.
By their numbers in this assay, from the lowest: compound 2; then compound 1; then compound 3. At a limit, above all of these: compound 4.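

At this carbonyl carbon, 1-methylcyclohexyl is the only group shown that gives no number in this assay, and compound 4 stands only at a limit: the limit of > 200 mg/kg in this assay, at which 1 of the 4 values shown sits. The steps are an at least 4.7-fold higher number from compound 3 to compound 4 (0.67 log units; beyond the scatter), an at least 180-fold higher number from compound 2 to compound 4 (2.25 log units; beyond the scatter) and an at least 64-fold higher number from compound 1 to compound 4 (1.80 log units; beyond the scatter). Furan-2-yl, with the highest number among the earlier compounds, therefore does not mark the poor end of what this position allows.

The compounds shown leave open whether the carbon ring itself or its added methyl accounts for this change. Plain cyclohexyl and unsubstituted phenyl would help separate these possibilities.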